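Halogenated benzyl variations on a shared nucleoside core

The source may report more compounds than this note shows. Statements on the series, on what has been measured and on what is new or still open speak of the compounds shown alone.

The series holds compound 1 `OC[C@H]1O[C@@H](n2cnc3c(NCc4ccccc4Cl)ncnc32)[C@H](O)[C@@H]1O`, compound 2 `OC[C@H]1O[C@@H](n2cnc3c(NCc4cccc(Br)c4)ncnc32)[C@H](O)[C@@H]1O`, compound 3 `OC[C@H]1O[C@@H](n2cnc3c(NCc4ccc(F)cc4F)ncnc32)[C@H](O)[C@@H]1O` and the not yet measured compound 4 `OC[C@H]1O[C@@H](n2cnc3c(NCc4ccc(F)cc4Cl)ncnc32)[C@H](O)[C@@H]1O`. In a functional assay on HOS cells (Homo sapiens) for antiproliferative activity, with a stated time of 72 h (on this read-out lower numbers stand for stronger inhibition and higher numbers for weaker inhibition), compound 1 gives > 166000 nM, which is a limit of the assay. In this assay compound 2 gives > 166000 nM, also a limit. In this assay compound 3 gives > 166000 nM, again a limit. Compound 2 therefore stands at the limit of > 166000 nM in this assay, at which 3 of the 3 values shown sit. The steps a step that the two limits leave unreadable from compound 1 to compound 2, a step that the two limits leave unreadable from compound 1 to compound 3 and a step that the two limits leave unreadable from compound 2 to compound 3 are all unreadable. Compound 4 differs from compound 2 by 2-chloro-4-fluorophenyl in place of 3-bromophenyl on a saturated chain carbon bound to a nitrogen on an aromatic ring. Because the limit of > 166000 nM in this assay, at which 3 of the 3 values shown sit, holds every value shown, no direction and no size beyond the scatter can be read for the new change in this assay. Compound 4 is expected to give 200000 nM, within 100000 nM to 500000 nM. The estimated step is a step that the limit leaves unreadable from compound 2 to compound 4.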

Compound 4, half-maximal inhibitory concentration: > 166000 nM
Compound 4: only a limit was reported; the forecaster's own chance of this, stated with the estimate: 85%; the middle value is on the limit's open side.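

No new step can be read for compound 4 against compound 1, compound 2 or compound 3 in this assay, since all four sit at one limit: the limit of > 166000 nM in this assay, at which 4 of the 4 values shown sit. On these data alone, whether any benzyl change on the shared core shifts this read-out stays open.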